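Hydroxymethylbenzyl in place of fluorobenzyl: solubility

The source may hold more compounds than are shown below. What is called first, only, known or untested is meant among the compounds shown, and "the series" means these compounds.

Compound 1 `Cc1noc(-c2nc(C)c3c(c2N)C(=O)N(Cc2ccc(F)cc2)C3=O)n1`: < 5000 nM
Compound 2 `Cc1noc(-c2nc(C)c3c(c2N)C(=O)N(Cc2ccc(Oc4ccc(F)cc4)cc2)C3=O)n1`: 23800 nM
Compound 3 `Cc1noc(-c2nc(C)c3c(c2N)C(=O)N(Cc2ccccc2F)C3=O)n1`: < 5000 nM

In a physicochemical assay for solubility, using the shake flask method, in simulated intestinal fluid, measured as kinetic solubility, with a stated time of 2 h, at 25 degrees C, at pH 6.5 (a higher number here means a more soluble compound, a lower number a less soluble compound), compound 3 gives only a limit, < 5000 nM. Compound 1 likewise sits at a limit, < 5000 nM. Compound 2 gives a number, 23800 nM, and an at least 4.7-fold higher number from compound 1 to compound 2 (0.67 log units; beyond the scatter). The step that the two limits leave unreadable from compound 1 to compound 3. Two of the three values sit at the limit of < 5000 nM in this assay, at which 2 of the 3 values shown sit. Compound 4 `Cc1noc(-c2nc(C)c3c(c2N)C(=O)N(Cc2ccc(CO)cc2)C3=O)n1` differs from compound 3 by 4-(hydroxymethyl)phenyl in place of 2-fluorophenyl on a saturated chain carbon bound to an amide-type nitrogen in a ring. For the measured compounds named here, no measured step covers a hydroxymethyl group, so the estimate rests on the range that the limits leave open. Compound 4 is expected to give 12000 nM, between 4000 nM and 40000 nM. That would mean an expected step of an at least 2.4-fold higher number from compound 3 to compound 4 (0.38 log units; beyond the scatter), with a fair chance that this assay again reports only a limit.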

Compound 4, solubility: < 5000 nM
Compound 4 ended at the assay's limit; the forecaster's own chance of this, stated with the estimate: 35%; middle value at least 2.4-fold (0.38 log units) away from the limit.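

In this assay compound 4 gives < 5000 nM, which is a limit and not a number. Hydroxymethyl on this aromatic carbon, in place of 4-fluorophenoxy, gives an at least 4.7-fold lower number from compound 2 to compound 4 (0.67 log units; beyond the scatter). The steps from compound 1 and compound 3 to compound 4 cannot be read, and compound 2 alone now stands clear of the shared limit: the limit of < 5000 nM in this assay, at which 3 of the 4 values shown sit.

Going by these compounds, how compound 1, compound 3 and compound 4 rank against one another stays unknown. On these data alone, whether an amine, a carboxylic acid or a longer ether chain on that aromatic carbon would also clear the limit remains open.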